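Replacing 3,4-dimethoxyphenyl with 4-fluorophenyl in compound 3

The source may hold more compounds than are shown below. What is called first, only, known or untested is meant among the compounds shown, and "the series" means these compounds.

Measured in a functional assay on SW480 cells (Homo sapiens) for cytotoxicity, read by sulforhodamine B assay, with a stated time of 48 h; on this read-out higher numbers stand for weaker inhibition and lower numbers for stronger inhibition:
- compound 1 `COc1ccc(/C=C/C(=O)c2cccc(-c3ccc(F)cc3)c2)cc1` gives 8350 nM
- compound 2 `COc1cc(/C=C/C(=O)c2ccc(N)c(-c3ccc(F)cc3)c2)ccc1O` gives 8350 nM
- compound 3 `COc1ccc(-c2cc(C(=O)/C=C/c3cc(OC)c(OC)c(OC)c3)ccc2N)cc1OC` gives 5630 nM

These three values sit close together. Compound 3 gives 5630 nM, and its gaps to compound 1 and compound 2 lie within the usual scatter of repeated measurements, so the numbers set no order among them.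

Compound 4 `COc1cc(/C=C/C(=O)c2ccc(N)c(-c3ccc(F)cc3)c2)cc(OC)c1OC` is still unmeasured. Compared with compound 3, it has 4-fluorophenyl in place of 3,4-dimethoxyphenyl on an aromatic carbon, ortho to an amino group: 4-fluorophenyl in place of 3,4-dimethoxyphenyl on an aromatic carbon. Among the measured compounds shown here, no two measured compounds differ in one place only, so this change has no direct precedent. For the measured compounds named here, still, compound 2 also carries 4-fluorophenyl and gives 8350 nM, a value within the scatter of the one for compound 3. The estimated 1.2-fold higher number from compound 3 to compound 4 (0.09 log units; within the scatter) is therefore expected to stay within the scatter in this assay, with no firm direction. For compound 4 the estimated value is 7000 nM, with an expected range from 3500 nM to 14000 nM.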

Compound 4, half-maximal inhibitory concentration: 6120 nM
The estimate for compound 4 lay 1.1-fold (0.06 log units) above the measured number; the measured number falls inside the stated range.
By their numbers in this assay, from the lowest: compounds 3, 4, 1 and 2 (each within the scatter of the next).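

Among the compounds shown here, the step of a 1.1-fold higher number from compound 3 to compound 4 (0.04 log units; within the scatter) in this assay gives the first direct reading of this change, because these two compounds differ in one place only. On this aromatic carbon, ortho to an amino group, the group goes from 10 heavy atoms to 7 and from 2 hydrogen-bond acceptors to 0, yet the step stays within the scatter, so this pair shows no measurable effect of the exchange. Nothing measured here offers an explanation for this result.

Going by these compounds, whether this position tolerates any group or only these two aromatic rings stays open, and a carboxylic acid, an amine or a small methyl group there would test that. Also open, on these data alone, is whether the exchange reads the same way on a different core or in other cell types.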